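The source may report more compounds than this note shows. Statements on the series, on what has been measured and on what is new or still open speak of the compounds shown alone.

Compound 1 `CNC(=O)/C=C1/COc2cc(OS(=O)(=O)c3ccc(OC)cc3)ccc21`: 11 nM in an assay (strain Sprague-Dawley) for inhibition of Amine oxidase [flavin-containing] A (Rattus norvegicus), read by spectrophotometry, with a stated time of 5 min; a higher number here means a weaker inhibitor, a lower number a stronger inhibitor
Compound 2 `CNC(=O)/C=C1/COc2c1ccc(OS(=O)(=O)c1cccc(Cl)c1)c2C`: 24 nM
Compound 3 `CNC(=O)/C=C1/COc2c1ccc(OS(=O)(=O)c1ccc(C#N)cc1)c2C`: 15 nM

Compound 3 stands second highest of the three numbers in this assay; its nearest neighbour is compound 1, and its furthest is compound 2, both within the scatter. For the measured compounds named here, the only single-point step among the measured compounds is a 1.6-fold lower number from compound 2 to compound 3 (0.20 log units; within the scatter), and that step swaps 3-chlorophenyl for 4-cyanophenyl, a different change from the one now considered.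

Compound 4 `CNC(=O)/C=C1/COc2c1ccc(OS(=O)(=O)c1ccc(OC)cc1)c2C` differs from compound 3 by methoxy in place of cyano on an aromatic carbon. Going by the values given here, no measured step exchanges cyano for methoxy on this ring, so the expectation rests on what the values show. Compound 1 carries the same 4-methoxyphenyl on the sulfonyl sulfur as compound 4, though on a different core, and the values of compound 1 and compound 3 lie within the scatter of each other. Taken with the small size of the step from compound 2 to compound 3, this suggests that changing the para substituent on the sulfonyl ring moves the number little. Compound 4 is therefore expected to show a 1.2-fold lower number from compound 3 to compound 4 (0.06 log units; within the scatter), a step not beyond the scatter, with an estimated value of 13 nM and a range from 6 nM to 30 nM.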

Compound 4, half-maximal inhibitory concentration: 7 nM
Compound 4: middle estimate off by 1.9-fold (0.27 log units), on the high side; the measured number falls inside the stated range.
By their numbers in this assay, from the lowest: compounds 4, 1, 3 and 2 (each within the scatter of the next, the first and the last beyond it).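

In this assay, for the compounds shown here, methoxy in place of cyano on the aromatic carbon para to a large group is the first change on the sulfonyl ring here to go beyond the scatter, a 2.1-fold lower number from compound 3 to compound 4 (0.33 log units; beyond the scatter), though the step is modest, so the group at this position does register on the shared core. The wider exchange of 3-chlorophenyl for 4-methoxyphenyl gives a 3.4-fold lower number from compound 2 to compound 4 (0.54 log units; beyond the scatter), also modest, while with 4-methoxyphenyl held fixed, methyl in place of hydrogen on an aromatic carbon gives only a 1.6-fold lower number from compound 1 to compound 4 (0.20 log units; within the scatter), so that methyl cannot be told apart from no change. Nothing available explains why methoxy and cyano differ at this position.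

On these data alone, the step from 3-chlorophenyl to 4-methoxyphenyl changes both the group and where it sits, so these compounds cannot show how much of it belongs to each, and the effect of a chlorine at the position held by methoxy in compound 4 stays open. As far as these compounds go, it also remains open whether a longer chain such as ethoxy, or an amine or a hydroxyl group, at that position would follow methoxy or cyano.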